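Benzothiazole amides: methoxy to trifluoromethyl on the benzamide ring

The compounds below may be only part of what the source reports. "The series", "measured", "known", "first", "only" and "open" are said of these compounds alone.

Measured so far:
compound 1 `Cc1cc(C)c2sc(NC(=O)c3ccc(C(F)(F)F)cc3)nc2c1` — 1.36 ug/mL
compound 2 `COc1ccc2nc(NC(=O)c3ccc(C)cc3)sc2c1` — > 10 ug/mL
compound 3 `COc1ccc(C(=O)Nc2nc3c(OC)cccc3s2)cc1` — 2.11 ug/mL

In a functional assay on SK-HEP1 cells (Homo sapiens) for antiproliferative activity, read by sulforhodamine B assay (on this read-out higher numbers stand for weaker inhibition of growth and lower numbers for stronger inhibition of growth), compound 3 gives 2.11 ug/mL, the higher of the two numbers in hand. Its nearest neighbour is compound 1, which gives 1.36 ug/mL; the gap between the two lies within the scatter, so no order between them can be claimed. For compound 2 the assay reports only a limit, > 10 ug/mL (the limit of > 10 ug/mL in this assay, at which 1 of the 3 values shown sits), and not a number.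

Compound 4 `COc1cccc2sc(NC(=O)c3ccc(C(F)(F)F)cc3)nc12` is not yet measured. It differs from compound 3 in one place: trifluoromethyl in place of methoxy on an aromatic carbon. The same trifluoromethyl sits on the benzamide ring of compound 1, whose value stands close to that of compound 3, but since the two cores also differ, only the two values themselves can be read.

On that basis the step from compound 3 to compound 4 is expected to be small and toward somewhat stronger growth inhibition, if anything, a 1.4-fold lower number from compound 3 to compound 4 (0.15 log units; within the scatter), with a fair chance of no change beyond the scatter. Compound 4 is therefore estimated at 1.5 ug/mL in this assay, within 0.6 ug/mL to 4 ug/mL.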

Compound 4, concentration for 50% growth inhibition: > 10 ug/mL
Compound 4 was reported as a limit; the forecaster's own chance of this, stated with the estimate: 10%; middle value at least 6.6-fold (0.82 log units) away from the limit.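

Going by these compounds alone, this is the first step that can be read at a single position: in this assay, trifluoromethyl in place of methoxy on the six-membered aromatic ring of carbon only, para to a large group, gives an at least 4.7-fold higher number from compound 3 to compound 4 (0.67 log units; beyond the scatter). On the core shared by compound 3 and compound 4, growth inhibition therefore depends on which of these two groups occupies this position, and trifluoromethyl does not stand in for methoxy. The value of compound 4 is a limit and not a number, so the full size of the step stays unknown: the limit of > 10 ug/mL in this assay, at which 2 of the 4 values shown sit.

As far as these compounds go, whether methoxy is unusual at this position or trifluoromethyl alone loses growth inhibition remains open. An amine, a hydroxyl or a longer alkoxy chain here would help to separate the two readings.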